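This account rests on a few compounds, and the source may have more. Where it says the series, first, only, none or still open, it means among the compounds named here.

Measured compounds:
- compound 1, `COc1ccc2c(c1)CCC2CCCN1CCCC(C)(C)C1`: in an assay on cell membranes for binding affinity to Sigma non-opioid intracellular receptor 1 (Rattus norvegicus), read by radioligand binding (a higher number here means a weaker inhibitor, a lower number a stronger inhibitor), compound 1 gives 4660 nM
- compound 2, `COc1cccc2c1CCC2CCCCN1CCCC(C)(C)C1`: in this assay compound 2 gives 9.3 nM
- compound 3, `CC1(C)CCCN(CCCC2CCCc3ccccc32)C1`: in this assay compound 3 gives 252 nM

Compound 3 carries no substituent on the aromatic ring of the shared core and a three-carbon chain to the amine. Of the three numbers it stands second highest: compound 1 sits well above it, and compound 2 sits well below it, both gaps beyond the scatter. No two of the three compounds differ in one place only, so neither gap can be read as a single step; compound 2 differs from compound 3 in both the aromatic substituent and the chain length.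

Compound 4, `CC1(C)CCCN(CCCC2CCCc3c(O)cccc32)C1`, has not yet been measured. It differs from compound 3 by hydroxy in place of hydrogen on an aromatic carbon. The only aromatic substituent measured at a comparable place is the methoxy of compound 2, which together with its longer chain goes with the lowest number seen. Absent a clean pair for this change, the expectation for this assay is a step down from compound 3 of moderate size, beyond the scatter but smaller than the gap to compound 2, which is the expected step of a 2.5-fold lower number from compound 3 to compound 4 (0.40 log units; beyond the scatter). Compound 4 is therefore estimated at 100 nM, with a range from 25 nM to 500 nM.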

Compound 4, half-maximal inhibitory concentration: 41 nM
For compound 4 the middle estimate is 2.4-fold (0.39 log units) above the measured one, and the stated range covers the measured number.
By their numbers in this assay, from the lowest: compound 2; then compound 4; then compound 3; then compound 1.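

The series now holds its first pair differing in one place, so the aromatic position can be read on its own in this assay, where hydroxy in place of hydrogen on an aromatic carbon, ortho to a fused ring and meta to a fused ring, gives a 6.1-fold lower number from compound 3 to compound 4 (0.79 log units; beyond the scatter), a step beyond the scatter. This shows that the position accepts a hydroxy and that the number falls with it, which compound 1 and compound 2 could not show, since neither forms a one-place pair with any other compound. No measured evidence bears on what lies behind this step.

All other gaps among the four compounds join changes in more than one place and cannot be read as steps, so the separate contributions of chain length and aromatic substituent remain unresolved. Also open, going by these compounds, is whether a methoxy, a fluorine or an amine on the same aromatic carbon would move the number as the hydroxy does, and whether the hydroxy step would hold with a longer chain to the amine.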